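The source may report more compounds than this note shows. Statements on the series, on what has been measured and on what is new or still open speak of the compounds shown alone.

Measured in an assay on cells for inhibition of cytochrome P450 11B2, mitochondrial (Homo sapiens), read by HTRF; a higher number here means a weaker inhibitor, a lower number a stronger inhibitor:
- compound 1 `Cc1cc(Cl)ccc1C(=O)N(C)c1cccnc1` gives > 3000 nM, which is a limit of the assay, not a number.
- compound 2 `CC(=O)N1CCC(Oc2cncc(N3C(=O)c4ccc(Cl)cc4C3(C)C)c2)CC1` gives 4 nM.
- compound 3 `N#Cc1ccc2c(c1)CN(c1cccnc1)C2=O` gives 232 nM.

Compound 1 thus stands at the weak end of what has been measured; its value is only a limit, and that is the point at which (the limit of > 3000 nM in this assay, at which 1 of the 3 values shown sits). Compound 2 and compound 3 both give numbers, and compound 2 sits well below compound 3.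

Compound 4 `CN(C(=O)c1ccc(Cl)cc1F)c1cccnc1` has not yet been measured. It differs from compound 1 by fluoro in place of methyl on an aromatic carbon; the place is on an aromatic carbon of a six-membered aromatic ring of carbon only, ortho to a large group and meta to the chloro group. The shared core of compound 1 and compound 4 is otherwise kept.

Among the measured compounds shown here, no measured pair shows this exchange, so the size of the step is open. Since compound 1 already sits at a limit, compound 4 is expected to stay in the weak range, with a step from compound 1 to compound 4 of an at least 1.2-fold lower number from compound 1 to compound 4 (0.07 log units; that floor lies within the scatter) that is estimated as no more than the scatter. For compound 4 the expected value is 2500 nM, in an estimated range from 700 nM to 9000 nM.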

Compound 4, half-maximal inhibitory concentration: > 3000 nM
Compound 4 was reported as a limit (the forecaster's own chance of this, stated with the estimate: 55%); at least 1.2-fold (0.07 log units) between middle value and limit.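

Compound 1 and compound 4 are both reported only as limits in this assay, so no step between them can be read: the limit of > 3000 nM in this assay, at which 2 of the 4 values shown sit.

The compounds shown leave open whether fluoro in place of methyl on an aromatic carbon shifts the inhibition in either direction.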